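This account rests on a few compounds, and the source may have more. Where it says the series, first, only, none or still open, it means among the compounds named here.

Measured so far:
compound 1 `CC(=O)Oc1ccccc1C(=O)O[C@H]1CO[C@H]2[C@@H]1OC[C@H]2OC(=O)c1ccccc1O` — 0.0825 h
compound 2 `CC(=O)Oc1ccccc1C(=O)O[C@H]1CO[C@H]2[C@@H]1OC[C@H]2OC(=O)c1ccc(C)cc1` — 0.105 h

Within the data shown here, in an ADME assay on a cell-free system (plasma, Homo sapiens) for metabolic stability, with Plasma (Rattus norvegicus) as the target, read by HPLC, at pH 7.4 (a lower number here means that the compound disappears faster, a higher number that the compound lasts longer), compound 2 gives 0.105 h, and the only other number, that of compound 1, lies within the scatter of it: a 1.3-fold higher number from compound 1 to compound 2 (0.10 log units; within the scatter). So the two measured compounds cannot be told apart on these data.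

Compound 3 `CC(=O)Oc1ccccc1C(=O)O[C@H]1CO[C@H]2[C@@H]1OC[C@H]2OC(=O)c1ccncc1` differs from compound 2 by pyridin-4-yl in place of 4-methylphenyl on a carbonyl carbon. Among the measured compounds shown here, the one measured step, a 1.3-fold higher number from compound 1 to compound 2 (0.10 log units; within the scatter), concerns the same carbonyl-bound ring but swaps different groups, and it stayed within the scatter; no measured step involves a pyridin-4-yl group. With no evidence for a shift in either direction, the step of a 1.2-fold lower number from compound 2 to compound 3 (0.07 log units; within the scatter) is expected to stay within the scatter, perhaps slightly lower. Compound 3 is therefore expected to give 0.09 h. For compound 3 the expected range runs from 0.045 h to 0.18 h.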

Compound 3, half-life: 0.0617 h
Compound 3: the middle estimate sits 1.5-fold (0.16 log units) above what was measured; measured number inside the range.
By their numbers in this assay, from the lowest: compounds 3, 1 and 2 (each within the scatter of the next).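

In this assay, the swap to pyridin-4-yl on this carbonyl carbon gives a 1.7-fold lower number from compound 2 to compound 3 (0.23 log units; within the scatter), and the same place read against the 2-hydroxyphenyl ester gives a 1.3-fold lower number from compound 1 to compound 3 (0.13 log units; within the scatter). Among these compounds, with the earlier step, this means that a six-membered aromatic ring with a hetero atom now joins the two carbon-only rings at this place, and no pair among the three compounds is separated beyond the scatter. Nothing available bears on why the numbers fall as they do.

Going by these compounds, whether a group of another kind at this place, such as a longer alkyl chain, an amine or a carboxylic acid, would separate from these three remains open. The compounds also leave open how a change to the other ester on the shared core, identical in all three, would read, and which ester bond is lost.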